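This account rests on a few compounds, and the source may have more. Where it says the series, first, only, none or still open, it means among the compounds named here.

Working notes on the series. Compound 1 `O=C(Nc1ccccc1C(F)(F)F)c1cc(Cl)ccc1O` carries the shared core; in an ADME assay on cells (Macrophage, Mus musculus) for cytotoxicity, read by resazurin assay, with a stated time of 3 days (on this read-out higher numbers stand for weaker inhibition and lower numbers for stronger inhibition), compound 1 gives 19000 nM. Compound 2 `O=C(Nc1ccc(F)cc1C(F)(F)F)c1cc(Cl)ccc1O` differs from it by fluoro in place of hydrogen on an aromatic carbon, and in this assay compound 2 gives 13000 nM. Compound 3 `O=C(Nc1ccc(F)c(F)c1)c1cc(Cl)ccc1O` gives 7700 nM in this assay; how the core of compound 3 differs from that of compound 1 is not broken down here. Compound 3 and compound 2 lie within the scatter of each other, while the gap from compound 3 to compound 1 is beyond it.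

Compound 4 `O=C(Nc1ccc(F)c(F)c1F)c1cc(Cl)ccc1O` is not yet measured. It differs from compound 3 by fluoro in place of hydrogen on an aromatic carbon. This is the same kind of change as from compound 1 to compound 2, but the place is not the same: there the entering fluoro stood meta to a trifluoromethyl group and para to a large group, here it stands ortho to a fluoro group, ortho to a large group and meta to a fluoro group. The earlier step was a 1.5-fold lower number from compound 1 to compound 2 (0.16 log units; within the scatter).

The expected step here, a 1.3-fold lower number from compound 3 to compound 4 (0.11 log units; within the scatter), is kept small because a 1.5-fold lower number from compound 1 to compound 2 (0.16 log units; within the scatter) is all that this kind of change has produced so far, and it rests on compound 3 at 7700 nM. Compound 4 is therefore estimated at 6000 nM in this assay. For compound 4 the expected range runs from 3000 nM to 14000 nM.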

Compound 4, half-maximal inhibitory concentration: 6700 nM
Compound 4: middle estimate off by 1.1-fold (0.05 log units), on the low side, and the stated range covers the measured number.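

In this assay fluoro in place of hydrogen on an aromatic carbon gives a 1.1-fold lower number from compound 3 to compound 4 (0.06 log units; within the scatter) and this can be set beside the earlier step on the other core: the same change on two cores in this assay, a 1.5-fold lower number (0.16 log units; within the scatter) from compound 1 to compound 2 and a 1.1-fold lower number (0.06 log units; within the scatter) from compound 3 to compound 4, 1.3-fold (0.10 log units) apart, within the scatter of two such steps. The change therefore carries from the core of compound 1 to the core of compound 3 without a difference that can be told from scatter, and on both cores its step stays small, even though the entering fluoro stands in a different place on each. Among these compounds, this does not show that the change has a real effect on the number on either core, since each step lies within the scatter on its own, and with only two steps, differing in both core and place, the contributions of core and place cannot be separated.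

The compounds shown leave open whether a group other than fluoro entering at the same place, such as an amine, a methoxy group or a carboxylic acid, would give a step beyond the scatter. They also leave open whether the small step holds on further cores, for example one carrying a nitrile in place of the trifluoromethyl group of compound 2.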